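One Substitution on a Shared Core Under Cytotoxicity Testing

This account rests on a few compounds, and the source may have more. Where it says the series, first, only, none or still open, it means among the compounds named here.

Compound 1 `CCC[C@@H](OC(C)=O)C1=C(Br)C(=C(Br)Br)OC1=O`: 2.1 ug/mL
Compound 2 `CCCCC1=C(Br)C(OC)(C(Br)Br)OC1=O`: 6.6 ug/mL
Compound 3 `CCCCC1=C(Br)/C(=C/Br)OC1=O`: 7.3 ug/mL

In a functional assay on LNCaP cells (Homo sapiens) for cytotoxicity (a lower number here means that less compound is needed, a higher number that more compound is needed for the effect), compound 1 gives the lowest of the three numbers, and its gaps to compound 2 and to compound 3 both lie beyond the usual scatter of repeated measurements. Compound 4 `CCCCC1=C(Br)C(=C(Br)Br)OC1=O` has not yet been measured. It differs from compound 1 in a single place: hydrogen in place of acetoxy on a saturated chain carbon bound to a double-bonded ring carbon and a saturated chain carbon. Compound 2 and compound 3 also carry hydrogen rather than acetoxy on their chain, and a rise toward their level is expected because compound 2 gives 6.6 ug/mL and compound 3 gives 7.3 ug/mL. The expected step is a 2.6-fold higher number from compound 1 to compound 4 (0.42 log units; beyond the scatter), beyond the scatter. Compound 4 is estimated at 5.5 ug/mL, within a range from 2.5 ug/mL to 12 ug/mL.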

Compound 4, concentration for half-maximal effect: 9.3 ug/mL
Compound 4: middle estimate off by 1.7-fold (0.23 log units), on the low side, within the range that was stated.
By their numbers in this assay, from the lowest: compound 1; then compounds 2, 3 and 4 (each within the scatter of the next).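

In this assay, exchanging acetoxy for hydrogen on the saturated chain carbon gives a clear rise (a 4.4-fold higher number from compound 1 to compound 4 (0.65 log units; beyond the scatter)), so the lower number of compound 1 is tied to this one place on the shared core. The earlier compounds shown here differed from compound 1 in more than one place and could not isolate this change. No evidence at hand explains the step.

As far as these compounds go, it remains open whether a hydroxyl, an amine or a longer ester in place of acetoxy would keep the number of compound 1.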